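From fluoro to nitro at the assay limit

The source may report more compounds than this note shows. Statements on the series, on what has been measured and on what is new or still open speak of the compounds shown alone.

Among the compounds with values here, in a functional assay on A549 cells (Homo sapiens) for inhibition (a higher number here means a weaker inhibitor, a lower number a stronger inhibitor), compound 1 (`COCCOc1cc(/C=C/c2ccc3ccccc3c2)ccc1OC`) gives 2990 nM and is the only compound so far with a true number. Compound 2 (`COc1ccc(/C=C/c2ccc3ccccc3c2)cc1`) shows > 5000 nM in this assay and that is a limit of the assay, not a number. Compound 3 (`COc1ccc(/C=C/c2ccc3ccccc3c2)cc1F`) also stands at a limit, > 5000 nM in this assay and so has no exact place on the scale.

Compound 4 (`COc1ccc(/C=C/c2ccc3ccccc3c2)cc1[N+](=O)[O-]`) carries nitro in place of fluoro on an aromatic carbon, ortho to a methoxy group and meta to a large group (nitro in place of fluoro on an aromatic carbon). Within the data shown here, no measured step makes this exact swap, so the nearest ones must serve. Hydrogen in place of 2-methoxyethoxy gives an at least 1.6-fold higher number from compound 1 to compound 2 (0.22 log units; that floor lies within the scatter) and fluoro in place of 2-methoxyethoxy gives an at least 1.6-fold higher number from compound 1 to compound 3 (0.22 log units; that floor lies within the scatter) in the same assay. Fluoro in place of hydrogen, the one step at the carbon that changes here, gives a step that the two limits leave unreadable from compound 2 to compound 3 and so offers no size to carry over. No clear step is therefore expected in this assay in either direction, and compound 4 is expected to land near the limit of > 5000 nM in this assay, at which 2 of the 3 values shown sit, and may well be reported only as a limit. As a step, the estimate is a step that the limit leaves unreadable from compound 3 to compound 4 and it is only an expectation. For compound 4 the estimated value is 5500 nM with 2500 nM to 12000 nM as the expected range.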

Compound 4, half-maximal inhibitory concentration: > 5000 nM
Compound 4: no number, only a limit; the forecaster's own chance of this, stated with the estimate: 65%; the middle value does not contradict the limit.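

Compound 4 gives > 5000 nM in this assay, which is a limit of the assay and not a number. Nitro, with 3 heavy atoms where fluoro has 1, therefore joins fluoro and hydrogen at this aromatic carbon, ortho to a methoxy group, without giving a measurable value, and the limit is now the most common result among these compounds: the limit of > 5000 nM in this assay, at which 3 of the 4 values shown sit. The only readable step is an at least 1.6-fold higher number from compound 1 to compound 4 (0.22 log units; that floor lies within the scatter), while the steps linking compound 4 to compound 2 and compound 3 cannot be read.

Hydrogen, fluoro and nitro at this carbon therefore cannot be ranked against one another, and any differences among them remain hidden beyond the limit. From the compounds shown here alone, it also remains open whether an amine or a carboxylic acid at the same carbon would give a true number, as the 2-methoxyethoxy compound 1 does.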